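Lengthening the chain on a chlorinated thiourea series

The source may hold more compounds than are shown below. What is called first, only, known or untested is meant among the compounds shown, and "the series" means these compounds.

Measured so far:
- Compound 1, `CCCNC(=S)NCCC(O)c1ccccc1N`: 31.1%
- Compound 2, `CNC(=S)NCCC(O)c1cc(Cl)ccc1N`: 22.1%
- Compound 3, `CCNC(=S)NCCC(O)c1cc(Cl)ccc1N`: 60.4%

In an assay for inhibition of Nitric oxide synthase, inducible (Homo sapiens), read by scintillation counting, with a stated time of 30 min, tested at 1 mM (on this read-out higher numbers stand for more inhibition at the one concentration tested (going by the name of the read-out) and lower numbers for less inhibition), compound 3 gives 60.4%, the highest of the three numbers, with compound 1 nearest and compound 2 furthest below it. Compound 4, `CCCNC(=S)NCCC(O)c1cc(Cl)ccc1N`, differs from compound 3 by methyl in place of hydrogen on a saturated chain carbon, two bonds along the chain from an amide-type nitrogen, read one bond further out as ethyl to propyl. Among the compounds with values here, the one measured step that bears on this is a number 38.3 percentage points higher from compound 2 to compound 3 (beyond the scatter), where the chain was likewise lengthened by one carbon, though one bond closer to the nitrogen. Compound 1 carries the propyl chain but lacks the chlorine, so its value does not settle the matter on its own. A modest change is expected, a number 1.6 percentage points higher from compound 3 to compound 4 (within the scatter), within the scatter. Compound 4 is therefore estimated at 62%, ranging from 38% to 84%.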

Compound 4, a percentage reported as inhibition, at one concentration (the size of the read-out at that concentration, not a potency): 55%
Beside the measured number, compound 4's estimate is 7 percentage points above it; the measured number falls inside the stated range.
By their numbers in this assay, from the lowest: compounds 2 and 1 (each within the scatter of the next); then compounds 4 and 3 (each within the scatter of the next).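

Lengthening ethyl to propyl gives a number 5.4 percentage points lower from compound 3 to compound 4 (within the scatter), so the large rise seen when methyl became ethyl is not repeated with the next carbon along the chain. The propyl compound still stands clear of the methyl one, with a number 32.9 percentage points higher from compound 2 to compound 4 (beyond the scatter). With the propyl chain held fixed, the chloro group also matters, with a number 23.9 percentage points higher from compound 1 to compound 4 (beyond the scatter).

Going by these compounds, whether a longer chain such as butyl, or a branched one such as isopropyl, would keep this level remains open. Nothing measured here explains any of these differences.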